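A Reversed Enone with Chlorine in a Flat Series

The compounds below may be only part of what the source reports. "The series", "measured", "known", "first", "only" and "open" are said of these compounds alone.

Compound 3 `COc1cc(-c2cc(C(=O)/C=C/c3ccc(C)cc3)nc3cc(-c4ccccc4)nn23)cc(OC)c1OC` gives 21900 nM in a functional assay on DU-145 cells (Homo sapiens) for antiproliferative activity, read by MTT assay, with a stated time of 24 h; a higher number here means a weaker inhibitor, a lower number a stronger inhibitor. Among the three measured compounds it holds the highest number, yet its neighbours sit within the scatter: compound 1 `COc1cc(-c2cc(C(=O)/C=C/c3ccccc3)nc3cc(-c4ccccc4)nn23)cc(OC)c1OC` gives 16300 nM and compound 2 `COc1ccc(/C=C/C(=O)c2cc(-c3cc(OC)c(OC)c(OC)c3)n3nc(-c4ccccc4)cc3n2)cc1` gives 16900 nM, and the steps of a 1.3-fold higher number from compound 1 to compound 3 (0.13 log units; within the scatter) and a 1.3-fold higher number from compound 2 to compound 3 (0.11 log units; within the scatter) are both within the scatter, as is a 1.0-fold higher number from compound 1 to compound 2 (0.02 log units; within the scatter). Compound 4 `COc1cc(-c2cc(/C=C/C(=O)c3ccc(Cl)cc3)nc3cc(-c4ccccc4)nn23)cc(OC)c1OC` differs from compound 3 by 2-((4-chlorophenyl)carbonyl)ethenyl in place of (2-(4-methylphenyl)ethenyl)carbonyl on an aromatic carbon. Among the compounds with values here, none of the measured steps bears directly on this exchange; each swapped only a methyl or methoxy for hydrogen on an aromatic carbon and stayed within the scatter. Because compound 3 gives 21900 nM with the steps of a 1.3-fold higher number from compound 1 to compound 3 (0.13 log units; within the scatter) and a 1.3-fold higher number from compound 2 to compound 3 (0.11 log units; within the scatter) both within the scatter, no step beyond the scatter is expected for a 1.2-fold lower number from compound 3 to compound 4 (0.09 log units; within the scatter). Compound 4 is therefore estimated at 18000 nM, with a range from 6000 nM to 55000 nM.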

Compound 4, half-maximal inhibitory concentration: 29300 nM
Estimate against measurement, compound 4: 1.6-fold (0.21 log units) below; the measured number falls inside the stated range.
By their numbers in this assay, from the lowest: compounds 1, 2, 3 and 4 (each within the scatter of the next).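

In this assay, the exchange to 2-((4-chlorophenyl)carbonyl)ethenyl, which reverses the enone on this aromatic carbon, gives a 1.3-fold higher number from compound 3 to compound 4 (0.13 log units; within the scatter) and a 1.7-fold higher number from compound 2 to compound 4 (0.24 log units; within the scatter) and a 1.8-fold higher number from compound 1 to compound 4 (0.25 log units; within the scatter). The series thus stays flat at this position even when the enone is turned around, which the earlier exchanges of hydrogen, methyl and methoxy on the outer ring could not show. Nothing available accounts for this flatness. The compounds shown do not separate the reversal from the chlorine, as the two arrive together. From the compounds shown here alone, whether an amine or a carboxylic acid on that outer ring would give a step beyond the scatter remains open.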